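Working notes: from compound 3 to compound 4

The compounds below may be only part of what the source reports. "The series", "measured", "known", "first", "only" and "open" are said of these compounds alone.

- compound 1 `CC1=NN(c2ccccc2)C(=O)[C@@]12C(=O)C=CC[C@@H]2c1ccc(C)cc1`: 6570 nM
- compound 2 `CC1=NN(c2ccccc2)C(=O)[C@]12C(=O)C=CC[C@H]2c1cccc(C)c1`: 13100 nM
- compound 3 `CC1=NN(c2ccccc2)C(=O)[C@@]12C(=O)C=CC[C@@H]2c1cccc(C)c1`: 4510 nM

In a functional assay on A549 cells (Homo sapiens) for inhibition, read by MTT assay, with a stated time of 72 h (on this read-out higher numbers stand for weaker inhibition and lower numbers for stronger inhibition), compound 3 stands at 4510 nM and cannot be separated from compound 1 (a 1.5-fold lower number from compound 1 to compound 3 (0.16 log units; within the scatter)). Its mirror image lies further off (a 2.9-fold lower number from compound 2 to compound 3 (0.46 log units; beyond the scatter)), a gap tied to configuration (the fact that compounds 2 and 3 differ only in the configuration as drawn).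

Compound 4 `COc1ccccc1[C@H]1CC=CC(=O)[C@@]12C(=O)N(c1ccccc1)N=C2C` keeps the shared core and changes one group (2-methoxyphenyl in place of 3-methylphenyl on a saturated ring carbon): 2-methoxyphenyl in place of 3-methylphenyl on a saturated ring carbon. Among the measured compounds shown here, the only measured step at this place is the one reaching compound 3 from compound 1 (a 1.5-fold lower number from compound 1 to compound 3 (0.16 log units; within the scatter)), so no step beyond the scatter is expected in this assay, although a methoxy group there is untested. The expected outcome is a 1.2-fold higher number from compound 3 to compound 4 (0.09 log units; within the scatter) for this change. For compound 4 the estimate is 5500 nM (expected range 2200 nM to 13500 nM).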

Compound 4, half-maximal inhibitory concentration: 18700 nM
Compound 4: the middle estimate sits 3.4-fold (0.53 log units) below what was measured, and the stated range ends below it.
By their numbers in this assay, from the lowest: compounds 3, 1, 2 and 4 (each within the scatter of the next, the first and the last beyond it).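

The position on the saturated ring carbon is not indifferent to its aryl group: in this assay, the swap between the two methylphenyl groups stayed within the scatter (a 1.5-fold lower number from compound 1 to compound 3 (0.16 log units; within the scatter)), but 2-methoxyphenyl weakens inhibition (a 4.1-fold higher number from compound 3 to compound 4 (0.62 log units; beyond the scatter)). The same holds against the 4-methylphenyl group (a 2.8-fold higher number from compound 1 to compound 4 (0.45 log units; beyond the scatter)). Nothing at hand bears on what lies behind these steps.

Open, going by these compounds, is whether the loss follows the methoxy group or its ring position, which a 2-methylphenyl or 3-methoxyphenyl group would separate. Also open, on these data alone, is how a phenyl group without substituents, or a dimethylaminophenyl group, would read here.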